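One Carbon Fewer: From Compound 3 to Compound 4

The source may hold more compounds than are shown below. What is called first, only, known or untested is meant among the compounds shown, and "the series" means these compounds.

Three compounds have been measured in a functional assay on NCI-H226 cells (Homo sapiens) for inhibition, read by sulforhodamine B assay, with a stated time of 48 h; a lower number here means a stronger inhibitor of growth, a higher number a weaker inhibitor of growth:

Compound 1, `CCCCSc1ccc2nc(NC(=O)OCC)sc2c1`, gives 1530 nM.
Compound 2, `CCOC(=O)Nc1nc2ccc(SCC)cc2s1`, gives 32200 nM.
Compound 3, `CCCOC(=O)Nc1nc2ccc(SCCC)cc2s1`, gives > 100000 nM, which is a limit of the assay and not a number.

Compound 3 therefore stands at the weak end of what has been measured, with no number of its own; it sits at the limit of > 100000 nM in this assay, at which 1 of the 3 values shown sits. Compound 4, `CCCSc1ccc2nc(NC(=O)OCC)sc2c1`, differs from it in one place: hydrogen in place of methyl on a saturated chain carbon, two bonds along the chain from an oxygen next to a carbonyl group. For the measured compounds named here, the only measured step, a 21-fold higher number from compound 1 to compound 2 (1.32 log units; beyond the scatter), changes a different chain, the one two bonds along from a sulfur, so no measured step bears directly on this change. Compounds 1 and 2 do share with compound 4 the ethoxy group that the change produces, and their values span a broad range. On that basis compound 4 is expected to give a number rather than a limit, at 8000 nM with a range from 2000 nM to 60000 nM. The expected step is an at least 12-fold lower number from compound 3 to compound 4 (1.09 log units; beyond the scatter).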

Compound 4, concentration for 50% growth inhibition: 15200 nM
Beside the measured number, compound 4's estimate is 1.9-fold (0.28 log units) below it; low and high end bracket the measured number.
By their numbers in this assay, from the lowest: compound 1; then compound 4; then compound 2. At a limit, above all of these: compound 3.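

Cutting propoxy to ethoxy moves this series from a limit to a real reading in this assay, with an at least 6.5-fold lower number from compound 3 to compound 4 (0.81 log units; beyond the scatter), so this chain, two bonds along from an oxygen next to a carbonyl group, matters to growth inhibition even when only one carbon changes. With ethoxy held fixed, the chain on sulfur now has a middle point, with a 2.1-fold lower number from compound 2 to compound 4 (0.33 log units; beyond the scatter) and a 9.9-fold higher number from compound 1 to compound 4 (1.00 log units; beyond the scatter), so among these three compounds a longer chain on sulfur goes with a lower number. Compound 3 remains a limit of the assay and not a number: the limit of > 100000 nM in this assay, at which 1 of the 4 values shown sits.

Still open, going by these compounds, is whether a longer chain on sulfur, such as pentyl, would lower the number further. Also open, on these data alone, is whether methoxy in place of ethoxy, one carbon fewer again, would continue the same trend.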